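The compounds below may be only part of what the source reports. "The series", "measured", "known", "first", "only" and "open" are said of these compounds alone.

Measured compounds:
compound 1 `CC1=CSC2=NC(/C=C/c3ccc(Br)cc3)=C(C(=O)/C=C/c3ccc(Br)cc3)C(c3ccccc3)N12` — 282 ug/mL
compound 2 `COc1ccc(/C=C/C(=O)C2=C(/C=C/c3ccc(OC)cc3)N=C3SC=C(C)N3C2c2ccccc2)cc1` — 358 ug/mL

Of the compounds shown here, two have been measured in an ADME assay on Vero cells (Chlorocebus sabaeus) for cytotoxicity, read by fluorescence and resazurin assay, with a stated time of 72 h; a higher number here means that more compound is tolerated, a lower number that less compound is tolerated. For the measured compounds named here, compound 1 `CC1=CSC2=NC(/C=C/c3ccc(Br)cc3)=C(C(=O)/C=C/c3ccc(Br)cc3)C(c3ccccc3)N12` gives 282 ug/mL and compound 2 `COc1ccc(/C=C/C(=O)C2=C(/C=C/c3ccc(OC)cc3)N=C3SC=C(C)N3C2c2ccccc2)cc1` gives 358 ug/mL; the two numbers lie within the scatter of one another, so no difference between them can be claimed, and compound 1 stands level with the only other measured compound. Going by the values given here, no pair of measured compounds differs in a single place, so no step has been measured.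

Compound 3 `CC1=CSC2=NC(/C=C/c3ccc(Br)cc3)=C(C(=O)/C=C/c3ccc(Br)cc3)C(c3ccc(Cl)cc3)N12` is not yet measured. It differs from compound 1 by chloro in place of hydrogen on an aromatic carbon. Nothing in the measured pair shows what such a change does here, so the expectation rests on the similarity of the two measured values. For compound 3 the expected step of a 1.2-fold lower number from compound 1 to compound 3 (0.07 log units; within the scatter) is small and not beyond the scatter. Compound 3 is estimated at 240 ug/mL in this assay, with a range from 130 ug/mL to 450 ug/mL.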

Compound 3, half-maximal cytotoxic concentration: 420 ug/mL
Compound 3: middle estimate off by 1.8-fold (0.24 log units), on the low side; the range from low to high includes it.
By their numbers in this assay, from the lowest: compounds 1, 2 and 3 (each within the scatter of the next).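

In this assay, for the compounds shown here, phenyl to 4-chlorophenyl gives the first single-place step, on an aromatic carbon para to a large group (a 1.5-fold higher number from compound 1 to compound 3 (0.17 log units; within the scatter)). Chloro in place of hydrogen at this position therefore stays within the scatter in this one pair, something compound 1 and compound 2 could not show, as they differ in more than one place. No measurement at hand explains the result.

Going by these compounds, it remains open whether an amine or a carboxylic acid at this position would give a step beyond the scatter. Also open, on these data alone, is whether chloro in place of hydrogen at the same position would read alike on the core of compound 2, with its two methoxy groups.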